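Aryl-to-benzyl switch at the fused-ring position

The source may report more compounds than this note shows. Statements on the series, on what has been measured and on what is new or still open speak of the compounds shown alone.

Compound 2 `FC(F)(F)c1ccc(-c2ccc3c(NCCCNCc4ccco4)ccnc3c2)cc1` gives 237 10^-6 cm/s in an ADME assay for permeability, using PAMPA, with a stated time of 30 min, at pH 7.4; on this read-out lower numbers stand for lower permeability and higher numbers for higher permeability. Compound 1 `COc1ccc(-c2ccc3c(NCCCNCc4cccc(OC)c4O)ccnc3c2)cc1` gives 237 10^-6 cm/s in this assay, level with compound 2 at the digits shown, and the two stand together highest of the three measured numbers. Compound 3 `COc1cccc(CNCCCNc2ccnc3cc(CCC(C)C)ccc23)c1O` gives 23 10^-6 cm/s in this assay, the lowest of the three. Among the compounds with values here, the one measured step at this position is a 10-fold lower number from compound 1 to compound 3 (1.01 log units; beyond the scatter), a large fall when an aryl group gives way to a saturated chain.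

Compound 4 `c1ccc(Cc2ccc3c(NCCCNCc4ccco4)ccnc3c2)cc1` carries benzyl in place of 4-(trifluoromethyl)phenyl on an aromatic carbon. Within the data shown here, no measured pair shows this exact exchange; the only guide is the fall from compound 1 to compound 3, where the aromatic ring was removed outright. In compound 4 the aromatic ring is kept but set one carbon further out and stripped of the trifluoromethyl group, so a smaller fall than that step is expected, though not none. Compound 4 is therefore expected to give 120 10^-6 cm/s in this assay, between 40 10^-6 cm/s and 300 10^-6 cm/s, which amounts to an expected step of a 2.0-fold lower number from compound 2 to compound 4 (0.30 log units; within the scatter).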

Compound 4, apparent permeability: 23 10^-6 cm/s
For compound 4 the middle estimate is 5.2-fold (0.72 log units) above the measured one, and the stated range ends above it.
By their numbers in this assay, from the lowest: compounds 3 and 4 (each within the scatter of the next); then compounds 1 and 2 (each within the scatter of the next).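

In this assay, the exchange at this position gives a 10-fold lower number from compound 2 to compound 4 (1.01 log units; beyond the scatter), a large step of the same printed size as a 10-fold lower number from compound 1 to compound 3 (1.01 log units; beyond the scatter), although here the leaving and the entering group each hold a six-membered aromatic ring of carbon only. Within the data shown here, in these two pairs, then, an aromatic ring in the entering group does not by itself keep the number high, which could not be read while the only step at this position went to isopentyl, a group with no such ring. No measured information on hand accounts for the size of this step.

Still open, as far as these compounds go, is which part of the exchange carries the step, since the link to the ring and the trifluoromethyl group change together. An unsubstituted phenyl or a 4-(trifluoromethyl)benzyl group on the same aromatic carbon would separate the two.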